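This account rests on a few compounds, and the source may have more. Where it says the series, first, only, none or still open, it means among the compounds named here.

Measured compounds in an ADME assay on MT4 cells (Homo sapiens) for cytotoxicity, read by MTT assay, with a stated time of 4 days; on this read-out lower numbers stand for higher toxicity in this test and higher numbers for lower toxicity in this test:
- compound 1 `Cc1cc(C#N)cc(C)c1Oc1ccnc(S(=O)(=O)CC(=O)Nc2ccccc2)n1`: 29300 nM
- compound 2 `Cc1cc(C#N)cc(C)c1Oc1ccnc(S(=O)(=O)CC(=O)Nc2ccc(Cl)cc2Cl)n1`: 10400 nM

Compound 1 stands highest of the two numbers; its nearest neighbour is compound 2, with a 2.8-fold lower number from compound 1 to compound 2 (0.45 log units; beyond the scatter). That single step is the only one available, and it replaces the aniline-derived phenyl with a disubstituted ring rather than a single substituent.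

Compound 3 `Cc1cc(C#N)cc(C)c1Oc1ccnc(S(=O)(=O)CC(=O)Nc2ccc(C#N)cc2)n1` differs from compound 1 by cyano in place of hydrogen on an aromatic carbon. For the measured compounds named here, the one measured step, from phenyl to a halogenated phenyl, moved the number modestly downward in this assay; a single cyano on the same ring is a smaller change, and no measured step shows what this group itself does. The expected step in this assay for compound 3 is therefore small, if anything downward, and likely within the scatter: a 1.3-fold lower number from compound 1 to compound 3 (0.12 log units; within the scatter). Compound 3 is estimated at 22000 nM, with a range from 9000 nM to 50000 nM.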

Compound 3, half-maximal cytotoxic concentration: >= 6010 nM
Compound 3 was reported as a limit; the forecaster's own chance of this, stated with the estimate: 20%; the middle value does not contradict the limit.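

In this assay, compound 3 gives >= 6010 nM, which is a limit and not a number. For the compounds shown here, no step from compound 1 or compound 2 to compound 3 can be read from it. Going by these compounds, what cyano in place of hydrogen on the aromatic carbon does in this assay remains open.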